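A few compounds are considered here, and "the series" means these few. Any claim that something is new, unique, unknown or untested is made for them only; others in the source may bear on it.

Measured compounds and their values:

Compound 1, `Nc1nc(Cl)c2ncn(Cc3ccc(CCl)cc3)c2n1`: 25700 nM
Compound 2, `ClCc1cccc(Cn2cnc3nc(Cl)nc(Cl)c32)c1`: 3540 nM
Compound 3, `ClCc1ccccc1Cn1cnc2nc(Cl)nc(Cl)c21`: 7240 nM

All three were tested in a functional assay on NCI-H522 cells (Homo sapiens) for cytotoxicity, read by sulforhodamine B assay, with a stated time of 48 h; on this read-out lower numbers stand for stronger inhibition of growth and higher numbers for weaker inhibition of growth. On the numbers in hand, compound 3 sits second highest of the three. Its nearest neighbour is compound 2, whose value is lower by a margin that goes beyond the scatter of repeated measurements, so compound 2 can be said to inhibit growth more strongly. Compound 1 lies furthest from compound 3, with a higher number, and that gap too exceeds the scatter; compound 3 therefore inhibits growth more strongly than compound 1.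

The next compound, compound 4, `ClCc1ccccc1Cn1cnc2ncnc(Cl)c21`, has not yet been measured in this assay. It differs from compound 3 in one place only: hydrogen in place of chloro on an aromatic carbon. The chloro that leaves sits on the shared core, on an aromatic carbon between two ring nitrogen atoms, meta to the other chloro group.

Within the data shown here, no measured pair in this set shows the effect of removing a chloro from that position, so the direction of the step cannot be read from the data. A modest weakening seems the more likely outcome, but a step of no more than the scatter would not be surprising. Compound 4 is expected to give about 10000 nM, within a range from 3500 nM to 30000 nM, which means an estimated step of a 1.4-fold higher number from compound 3 to compound 4 (0.14 log units; within the scatter).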

Compound 4, concentration for total growth inhibition: 75900 nM
Compound 4: the middle estimate sits 7.6-fold (0.88 log units) below what was measured; measured number above the stated range.
By their numbers in this assay, from the lowest: compound 2; then compound 3; then compound 1; then compound 4.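

In this assay, the chloro on the aromatic carbon between two ring nitrogen atoms proves to matter a great deal: putting hydrogen in its place gives a 10-fold higher number from compound 3 to compound 4 (1.02 log units; beyond the scatter). Among these compounds, this is the first pair in the set that differs in one place only, so it gives the first direct reading of a single change, and it shows that growth inhibition by compound 3 depends strongly on this one atom. Nothing available here accounts for the size of this loss, so the result records what happens without showing why.

The compounds shown place only chloro or hydrogen on this carbon within the series of compound 3 and compound 4, so it remains open whether a fluoro, a bromo or a methoxy group there would keep the growth inhibition of compound 3 or lose it as compound 4 does. A single pair also cannot tell whether removing the same chloro from compound 2 would cost as much.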